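A few compounds are considered here, and "the series" means these few. Any claim that something is new, unique, unknown or untested is made for them only; others in the source may bear on it.

Compound 1 `O=C(NCCCCN1CCN(c2ccccc2)CC1)c1ccc(-c2ccsc2)cc1` gives 0.41 h in an ADME assay on microsomes from liver (Rattus norvegicus) for metabolic stability, read by LC-MS, using NADPH; a higher number here means that the compound lasts longer, a lower number that the compound disappears faster. Compound 2 `O=C(NCCCCN1CCN(c2ccc(Cl)cc2)CC1)c1ccc(-c2ccsc2)cc1` gives 0.837 h in this assay, a change of a 2.0-fold higher number from compound 1 to compound 2 (0.31 log units; beyond the scatter). Compound 3 `N#Cc1cccc(N2CCN(CCCCNC(=O)c3ccc(-c4ccsc4)cc3)CC2)c1` reaches a limit of this assay, > 1 h, so only a floor is known for it (the limit of > 1 h in this assay, at which 1 of the 3 values shown sits). Against the first compound this is a change of an at least 2.4-fold higher number from compound 1 to compound 3 (0.38 log units; beyond the scatter), and against the second one of an at least 1.1-fold higher number from compound 2 to compound 3 (0.07 log units; that floor lies within the scatter). Compound 4 `N#Cc1ccc(N2CCN(CCCCNC(=O)c3ccc(-c4ccsc4)cc3)CC2)cc1` differs from compound 3 by 4-cyanophenyl in place of 3-cyanophenyl on an amine nitrogen in a ring. Going by the values given here, no measured pair changes only where the nitrile sits on that ring, so the size of this step is uncertain; the two earlier steps suggest that a substituted phenyl keeps the number high. Compound 4 is therefore expected to stay near the limit, at about 1.1 h, between 0.5 h and 2.5 h, a step that the limit leaves unreadable from compound 3 to compound 4.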

Compound 4, half-life: 0.22 h
Compound 4: the middle estimate sits 5.0-fold (0.70 log units) above what was measured; the whole stated range lies above it.
By their numbers in this assay, from the lowest: compounds 4 and 1 (each within the scatter of the next); then compound 2. At a limit, above all of these: compound 3.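

Moving the nitrile from 3-cyanophenyl to 4-cyanophenyl gives an at least 4.5-fold lower number from compound 3 to compound 4 (0.65 log units; beyond the scatter) in this assay, so where the nitrile sits on this ring counts, not only that it is present. The 4-cyanophenyl group also gives a 3.8-fold lower number from compound 2 to compound 4 (0.58 log units; beyond the scatter) and a 1.9-fold lower number from compound 1 to compound 4 (0.27 log units; within the scatter), so the rise seen with the earlier substituents on the phenyl ring does not hold for this one. Compound 3 stands at a limit, so the first step is only a floor: the limit of > 1 h in this assay, at which 1 of the 4 values shown sits.

Still open, on these data alone, is whether 3-chlorophenyl or 3-methoxyphenyl in the same place would follow the pattern of the two nitriles. As far as these compounds go, how far compound 3 really lies beyond its limit also stays unknown.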